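This account rests on a few compounds, and the source may have more. Where it says the series, first, only, none or still open, it means among the compounds named here.

Three compounds have been measured in an ADME assay on liver (Homo sapiens) for metabolic stability, read by LC-MS, using S9 fraction, tested at 2 uM; a higher number here means faster removal of the compound, a lower number slower removal:

- compound 1 `COc1ccc2nc(C)cc(OCC(=O)Nc3ccc4c(c3)CCC4)c2c1`: 16.9 mL/min/kg
- compound 2 `COc1ccc2nc(C)cc(OCC(=O)Nc3ccc(C)c(C)c3)c2c1`: 16.2 mL/min/kg
- compound 3 `COc1ccc2nc(C)cc(OCC(=O)Nc3ccc4c(c3)CCCC4)c2c1`: 15.6 mL/min/kg

All three share the same core and differ only in the group on the amide-type nitrogen. Compound 1 sits within the usual scatter of both compound 2 and compound 3, so the three numbers cannot be told apart. The step of a 1.0-fold lower number from compound 1 to compound 2 (0.02 log units; within the scatter) is the one that bears on the question here, since it also swaps the fused five-membered ring of compound 1 for an open-chain substituted phenyl, and it left this assay unchanged.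

Compound 4 `CCCc1ccc(NC(=O)COc2cc(C)nc3ccc(OC)cc23)cc1` has not yet been measured. Its change from compound 1 is 4-propylphenyl in place of 2,3-dihydro-1H-inden-5-yl on an amide-type nitrogen. Given that the comparable swap a 1.0-fold lower number from compound 1 to compound 2 (0.02 log units; within the scatter) stayed within the scatter, no step beyond the scatter is expected for compound 4 in this assay, so the expected step of a 1.0-fold lower number from compound 1 to compound 4 (0.01 log units; within the scatter) is essentially flat. Compound 4 is therefore estimated at 16.5 mL/min/kg, with a range from 9 mL/min/kg to 30 mL/min/kg.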

Compound 4, clearance in the liver assay: 12.7 mL/min/kg
Estimate against measurement, compound 4: 1.3-fold (0.11 log units) above, and the stated range covers the measured number.
By their numbers in the liver assay, from the lowest: compounds 4, 3, 2 and 1 (each within the scatter of the next).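

In the liver assay, the 4-propylphenyl group on the amide-type nitrogen gives a 1.3-fold lower number from compound 1 to compound 4 (0.12 log units; within the scatter) and a 1.3-fold lower number from compound 2 to compound 4 (0.11 log units; within the scatter), so a propyl chain with no second ring joins the fused five-membered ring and the 3,4-dimethylphenyl group among the changes at this position that stay within the scatter. The same change also stays within the scatter in a physicochemical assay for solubility, read by HPLC, measured as thermodynamic solubility, with a stated time of 24 h, at pH 1.5 (a higher number here means a more soluble compound, a lower number a less soluble compound), where compound 1 gives 240000 nM and compound 4 gives 260000 nM, which is a 1.1-fold higher number from compound 1 to compound 4 (0.03 log units; within the scatter). No available evidence bears on why these groups give such similar numbers.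

All the groups shown here on this nitrogen are built from carbon only and carry no hydrogen-bond donors or acceptors. As far as these compounds go, whether an amine or a carboxylic acid on the phenyl ring would leave either number this flat remains open.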